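A few compounds are considered here, and "the series" means these few. Any claim that something is new, unique, unknown or untested is made for them only; others in the source may bear on it.

The three measured compounds share one core and differ only in the aryl ring on the double-bonded chain. Compound 1 `COc1ccc(/C=C/C(=O)c2ccc(OC)c3c2OC(C)(C)C=C3)c(F)c1` carries a 2-fluoro-4-methoxyphenyl there. In a functional assay on K562 cells (Homo sapiens) for antiproliferative activity, read by MTT assay, with a stated time of 24 h (on this read-out lower numbers stand for stronger inhibition and higher numbers for weaker inhibition), compound 1 gives only a limit, > 10000 nM. Compound 2 `COc1ccc(C(=O)/C=C/c2cccc(F)c2)c2c1C=CC(C)(C)O2` carries a 3-fluorophenyl in its place. In this assay compound 2 likewise gives only a limit, > 10000 nM. Compound 3 `COc1ccc(C(=O)/C=C/c2cccc(Cl)c2)c2c1C=CC(C)(C)O2` carries a 3-chlorophenyl. In this assay compound 3 also gives only a limit, > 10000 nM. Compound 3 therefore stands where every value shown stands, at the limit of > 10000 nM in this assay, at which 3 of the 3 values shown sit. The steps among these three, a step that the two limits leave unreadable from compound 1 to compound 2, a step that the two limits leave unreadable from compound 1 to compound 3 and a step that the two limits leave unreadable from compound 2 to compound 3, are all of unreadable size, both ends of each sitting at the limit.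

Compound 4 `COc1ccc(C(=O)/C=C/c2cc(Cl)ccc2O)c2c1C=CC(C)(C)O2` differs from compound 3 by hydroxy in place of hydrogen on an aromatic carbon. Within the data shown here, no measured step bears on this change, and the three known steps give no size to work from. The expected step from compound 3 to compound 4, a step that the limit leaves unreadable from compound 3 to compound 4, is therefore anchored to nothing more than a limit. Compound 4 is expected to give about 15000 nM in this assay, within a range from 3000 nM to 50000 nM, most likely reported again only as a limit.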

Compound 4, half-maximal inhibitory concentration: 5510 nM
For compound 4 the middle estimate is 2.7-fold (0.43 log units) above the measured one; measured number inside the range.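

In this assay compound 4 is the only compound shown that gives a number rather than a limit, which makes hydroxy, ortho to a large group and para to a chloro group, the first change here with a step that can be read at all. That reading is an at least 1.8-fold lower number from compound 3 to compound 4 (0.25 log units; that floor lies within the scatter), and the replacement of the whole aryl ring by 5-chloro-2-hydroxyphenyl reads the same way, with an at least 1.8-fold lower number from compound 2 to compound 4 (0.25 log units; that floor lies within the scatter) and an at least 1.8-fold lower number from compound 1 to compound 4 (0.25 log units; that floor lies within the scatter). Each of these steps is only a floor that lies within the scatter, and the true sizes stay unknown because the other end of each step is a limit: the limit of > 10000 nM in this assay, at which 3 of the 4 values shown sit.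

From the compounds shown here alone, whether hydroxy has this effect without the chloro group, and whether a methoxy or an amine on the same aromatic carbon would also give a number rather than a limit, remains open. Going by these compounds, how far the real step from the 3-chlorophenyl to the 5-chloro-2-hydroxyphenyl compound exceeds its floor also remains open.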